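Series notes: hexyl to tert-butyl, compound 1 to compound 3

This account rests on a few compounds, and the source may have more. Where it says the series, first, only, none or still open, it means among the compounds named here.

Of the compounds shown here, two carry numbers so far. Compound 1 `CCCCCCOC(=O)/N=C(/N)c1ccc(NCc2nc3cc(C(=O)N(CCC(=O)OCc4nc(C)c(C)nc4C)c4ccccn4)ccc3n2C)cc1` has been tested in a functional assay on the whole organism (stomach, strain Sprague-Dawley) with Rattus norvegicus as the target, with stated times of 3 days and 4 h (a higher number here means that more compound is needed for the effect, a lower number that less compound is needed), and gives 2.1 mg/kg. Compound 2 `Cc1nc(C)c(CO)nc1C` is a much smaller structure; in this assay compound 2 gives 42.6 mg/kg. Compound 1 therefore holds the lowest of the two numbers, with compound 2 standing far above it, beyond the scatter. Going by the values given here, no pair of measured compounds differs in a single place, so no measured step is available to calibrate the next change.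

Compound 3 `Cc1nc(C)c(COC(=O)CCN(C(=O)c2ccc3c(c2)nc(CNc2ccc(/C(N)=N\C(=O)OC(C)(C)C)cc2)n3C)c2ccccn2)nc1C` is not yet measured. It differs from compound 1 by tert-butyl in place of hexyl on an oxygen next to a carbonyl group. Both chains are plain saturated carbon groups, and nothing in the measured pair speaks for a large shift, so a step from compound 1 to compound 3 of a 1.4-fold higher number from compound 1 to compound 3 (0.15 log units; within the scatter) is expected, a small rise that may well stay within the scatter. For compound 3 the estimate in this assay is 3 mg/kg, with a range from 1 mg/kg to 10 mg/kg.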

Compound 3, dose for half-maximal effect: 1.8 mg/kg
Beside the measured number, compound 3's estimate is 1.7-fold (0.22 log units) above it, within the range that was stated.
By their numbers in this assay, from the lowest: compounds 3 and 1 (each within the scatter of the next); then compound 2.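

Tert-butyl in place of hexyl on an oxygen next to a carbonyl group gives a 1.2-fold lower number from compound 1 to compound 3 (0.07 log units; within the scatter), the first single-place step available in this assay. This step lies within the scatter, so the assay does not separate these two groups at this position, even though hexyl carries more heavy atoms than tert-butyl. No measurement of any property of these groups accompanies the result.

The compounds shown cover only two plain saturated carbon groups here, so they leave open whether a longer chain, a benzyl group or a chain ending in an amine would also leave the number unchanged. They also leave open what happens when hexyloxycarbonyl or tert-butoxycarbonyl gives way to a bare hydrogen.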